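Benzothiazole amide series: cytotoxicity notes on compound 3

This account rests on a few compounds, and the source may have more. Where it says the series, first, only, none or still open, it means among the compounds named here.

Measured compounds:
compound 1 `O=C(Nc1nc2ccc(Cl)cc2s1)c1cc(-c2ccc(F)cc2)n2nc(-c3ccccc3)cc2n1`: 9770 nM
compound 2 `COc1ccc2nc(NC(=O)c3cc(-c4ccc(F)cc4)n4nc(-c5ccccc5)cc4n3)sc2c1`: 17300 nM

In a functional assay on HeLa cells (Homo sapiens) for cytotoxicity, read by MTT assay, with a stated time of 48 h (a lower number here means a stronger inhibitor, a higher number a weaker inhibitor), compound 2 gives 17300 nM, the highest of the two numbers; its nearest neighbour is compound 1, and the step of a 1.8-fold higher number from compound 1 to compound 2 (0.25 log units; within the scatter) lies within the scatter. Compound 3 `Cc1cc2nc(NC(=O)c3cc(-c4ccc(F)cc4)n4nc(-c5ccccc5)cc4n3)sc2cc1C` carries 5,6-dimethyl-1,3-benzothiazol-2-yl in place of 6-methoxy-1,3-benzothiazol-2-yl on an amide-type nitrogen. Among the measured compounds shown here, the one measured step, a 1.8-fold higher number from compound 1 to compound 2 (0.25 log units; within the scatter), also exchanges a group on this ring and stays within the scatter. For the measured compounds named here, no measured step exchanges methoxy for two methyl groups. Compound 3 is therefore expected to shift little, a 1.2-fold lower number from compound 2 to compound 3 (0.06 log units; within the scatter). The estimate for compound 3 is 15000 nM, within 5000 nM to 45000 nM.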

Compound 3, half-maximal inhibitory concentration: 18200 nM
Compound 3: the middle estimate sits 1.2-fold (0.08 log units) below what was measured; the measured number falls inside the stated range.
By their numbers in this assay, from the lowest: compounds 1, 2 and 3 (each within the scatter of the next).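

In this assay, 5,6-dimethyl-1,3-benzothiazol-2-yl in place of 6-methoxy-1,3-benzothiazol-2-yl gives a 1.1-fold higher number from compound 2 to compound 3 (0.02 log units; within the scatter), and in place of 6-chloro-1,3-benzothiazol-2-yl it gives a 1.9-fold higher number from compound 1 to compound 3 (0.27 log units; within the scatter). Both steps lie within the scatter, so two methyl groups read the same as a single chloro or methoxy, and this group on the amide-type nitrogen now spans three variants that cannot be told apart. Open, going by these compounds, is whether an amine or a carboxylic acid on the benzothiazole would move the number beyond the scatter, and whether any change on the shared core would. No measurement shown offers an explanation for these flat steps.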